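Ring swap on the chain carbon: compound 3 to compound 4

A few compounds are considered here, and "the series" means these few. Any claim that something is new, unique, unknown or untested is made for them only; others in the source may bear on it.

The three measured compounds share one core and differ only in the group on the side chain of the urea-type end. In an assay on membranes from Sf9 cells for displacement of a labelled ligand from histamine H2 receptor (Homo sapiens), read by scintillation counting, with a stated time of 60 min (on this read-out lower numbers stand for stronger inhibition and higher numbers for weaker inhibition), compound 1 `Cc1nc(N)sc1CCCN/C(N)=N/C(=O)NCC(C)CCc1ccccc1` gives 63.1 nM, compound 2 `Cc1nc(N)sc1CCCN/C(N)=N/C(=O)NCC(C)C1CCCCC1` gives 39.8 nM, and compound 3 `Cc1nc(N)sc1CCCN/C(N)=N/C(=O)NCC(C)CC1CCCCC1` gives 70.8 nM. Compound 3 has the highest number of the three, yet the steps leading to it, a 1.1-fold higher number from compound 1 to compound 3 (0.05 log units; within the scatter) and a 1.8-fold higher number from compound 2 to compound 3 (0.25 log units; within the scatter), both lie within the scatter, as does a 1.6-fold lower number from compound 1 to compound 2 (0.20 log units; within the scatter); the three compounds cannot be told apart on this read-out.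

Compound 4 `Cc1ccc(CC(C)CNC(=O)/N=C(\N)NCCCc2sc(N)nc2C)cc1` is the next step: 4-methylphenyl in place of cyclohexyl on a saturated chain carbon, three bonds along the chain from an amide-type nitrogen. The step that bears on it is a 1.1-fold higher number from compound 1 to compound 3 (0.05 log units; within the scatter), which exchanged an aromatic ring for a saturated one at the same place without a change beyond the scatter. Returning to an aromatic ring, now carrying a methyl, is therefore expected to give no step beyond the scatter in this assay, a 1.1-fold lower number from compound 3 to compound 4 (0.05 log units; within the scatter). For compound 4 the estimate is 63 nM, with a range from 25 nM to 160 nM.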

Compound 4, inhibition constant: 72.4 nM
Beside the measured number, compound 4's estimate is 1.1-fold (0.06 log units) below it, and the stated range covers the measured number.
By their numbers in this assay, from the lowest: compounds 2, 1, 3 and 4 (each within the scatter of the next).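

In this assay, the change to 4-methylphenyl on a saturated chain carbon, three bonds along the chain from an amide-type nitrogen, leaves the read-out unmoved within the scatter (a 1.0-fold higher number from compound 3 to compound 4 (0.01 log units; within the scatter)). The other two steps into compound 4 also stay within the scatter (a 1.1-fold higher number from compound 1 to compound 4 (0.06 log units; within the scatter); a 1.8-fold higher number from compound 2 to compound 4 (0.26 log units; within the scatter)), so a methyl-bearing aromatic ring joins the earlier side chains as indistinguishable on this read-out, and the series shows no preference here between a saturated and an aromatic ring. No supporting data offer an explanation for this flat result.

Every ring shown at this place is of carbon only, so the response to an amine, a carboxylic acid or a pyridine ring remains open. Also open, going by these compounds, is whether a methoxy or a hydroxyl in place of the methyl on the aromatic ring would stay within the scatter.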